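Fluoro in place of chloro on compound 1

The source may report more compounds than this note shows. Statements on the series, on what has been measured and on what is new or still open speak of the compounds shown alone.

In an in vitro ADME assay on microsomes (Homo sapiens) for metabolic stability (on this read-out higher numbers stand for a longer-lived compound and lower numbers for a shorter-lived compound), compound 1 `CCc1nc(NC(CC)CC)c(Cl)nc1-c1ccc(Cl)cc1Cl` gives 0.167 h while compound 2 `CCc1nc(-c2ccc(OC(F)(F)F)cc2OC)c(CC)nc1NC(CC)CC` gives 0.217 h and compound 3 `CCc1nc(-c2ccc(OC(C)C)cc2OC)c(CC)nc1NC(CC)CC` gives 0.183 h in the same read-out. Compound 1 stands within the scatter of both others, so no order can be read among the three.

The next change is fluoro in place of chloro on an aromatic carbon and it leads to compound 4 `CCc1nc(NC(CC)CC)c(F)nc1-c1ccc(Cl)cc1Cl` with fluoro in place of chloro on an aromatic carbon, ortho to a (pentan-3-yl)amino group.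

For the measured compounds named here, the one measured step is a 1.2-fold lower number from compound 2 to compound 3 (0.07 log units; within the scatter) and it concerns isopropyl in place of trifluoromethyl on an oxygen on an aromatic ring, so it bears on this change only loosely. Going by the values given here, no measured step exchanges chloro for fluoro at this place.

For this assay no step beyond the scatter is expected, and the estimate is a 1.1-fold higher number from compound 1 to compound 4 (0.03 log units; within the scatter) with no firm direction. Compound 4 is expected at 0.18 h with an estimated range from 0.1 h to 0.32 h as the working figure.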

Compound 4, half-life: 1.22 h
Compound 4: the middle estimate sits 6.8-fold (0.83 log units) below what was measured, and the stated range ends below it.
By their numbers in this assay, from the lowest: compounds 1, 3 and 2 (each within the scatter of the next); then compound 4.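

In this assay, for the compounds shown here, the exchange of chloro for fluoro gives a 7.3-fold higher number from compound 1 to compound 4 (0.86 log units; beyond the scatter) and is the first step in this set to lie beyond the scatter, since the one earlier step, a 1.2-fold lower number from compound 2 to compound 3 (0.07 log units; within the scatter), stays within it. The half-life of this series therefore responds to a single atom on the shared core, on the aromatic carbon next to the ring nitrogen and ortho to a (pentan-3-yl)amino group, while the rest of compound 4 stays as in compound 1. Nothing at hand accounts for the size of this step.

One exchange at one place leaves open whether other groups here, such as a nitrile, a methyl or an amine, would give a similar half-life. Also open, going by these compounds, is whether fluoro at this place would give a similar step alongside the aromatic groups of compound 2 and compound 3.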